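Diazepane for dimethylaminoethyl amine: cytotoxicity notes

The compounds below may be only part of what the source reports. "The series", "measured", "known", "first", "only" and "open" are said of these compounds alone.

Compound 1 `CN(C)CCN(C)c1ccc(C#N)c(CN2CCN([C@@H](c3ccccc3)c3ccc(Cl)cc3)CC2)c1` and compound 2 `CN1CCCN(c2ccc(C#N)c(CN3CCN([C@@H](c4ccccc4)c4ccc(Cl)cc4)CC3)c2)CC1` share a core that carries a nitrile; compound 3 `CN(C)CCN(C)c1ccc(C(F)(F)F)c(CN2CCN(C(c3ccccc3)c3ccc(Cl)cc3)CC2)c1` and compound 4 `CN1CCCN(c2ccc(C(F)(F)F)c(CN3CCN(C(c4ccccc4)c4ccc(Cl)cc4)CC3)c2)CC1` carry a trifluoromethyl group on the corresponding core. The difference between the two cores is not broken down here.

In a toxicity assay on Huh-7.5 cells (Homo sapiens) for cytotoxicity, read by MTT assay, with a stated time of 96 h (a higher number here means that more compound is tolerated, a lower number that less compound is tolerated), compound 1 gives 8780 nM. Compound 2 gives only a limit in this assay, > 20000 nM. The step is an at least 2.2-fold higher number from compound 1 to compound 2 (0.35 log units; beyond the scatter); the change behind it is 4-methyl-1,4-diazepan-1-yl in place of (2-(dimethylamino)ethyl)(methyl)amino on an aromatic carbon. That the step is open at one side follows from the limit of > 20000 nM in this assay, at which 1 of the 3 values shown sits. Compound 3 gives 6960 nM in this assay, which sits within the usual scatter of compound 1.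

Compound 4 is not yet measured in this assay. It differs from compound 3 by 4-methyl-1,4-diazepan-1-yl in place of (2-(dimethylamino)ethyl)(methyl)amino on an aromatic carbon. The same group leaves and the same group enters as between compound 1 and compound 2; the surroundings differ only in that the place is para to a cyano group there and para to a trifluoromethyl group here, so this is the same kind of change rather than the same one.

Among the compounds with values here, for compound 4 the expected step is a 2.6-fold higher number from compound 3 to compound 4 (0.41 log units; beyond the scatter), which rests on an at least 2.2-fold higher number from compound 1 to compound 2 (0.35 log units; beyond the scatter) as the single example of this change. Compound 4 is therefore estimated at 18000 nM. The range for compound 4 is expected to run from 10000 nM to 32000 nM, and a limit rather than a number is a real possibility given (the limit of > 20000 nM in this assay, at which 1 of the 3 values shown sits).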

Compound 4, half-maximal cytotoxic concentration: 1290 nM
Compound 4: middle estimate off by 14-fold (1.14 log units), on the high side; measured number outside the range, below it.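

In this assay, replacing (2-(dimethylamino)ethyl)(methyl)amino with 4-methyl-1,4-diazepan-1-yl on the trifluoromethyl-bearing core gives a 5.4-fold lower number from compound 3 to compound 4 (0.73 log units; beyond the scatter), so less compound is tolerated after the change on this core. Within this series, the change does not carry from one core to the other in either direction or size, and a step seen on the nitrile-bearing core is not a safe guide to the step on the trifluoromethyl-bearing core: the same change on two cores in this assay, an at least 2.2-fold higher number (0.35 log units; beyond the scatter) from compound 1 to compound 2 and a 5.4-fold lower number (0.73 log units; beyond the scatter) from compound 3 to compound 4, at least 12-fold (1.08 log units) apart, beyond the scatter of two such steps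

As far as these compounds go, compound 2 gives only a limit, > 20000 nM, so the full size of the step on the nitrile-bearing core stays open, and two pairs do not show which difference between the cores goes with the opposite directions.

Open, from the compounds shown here alone, is whether the two directions follow the nitrile and the trifluoromethyl group specifically, which a core with a chlorine atom or a methoxy group in their place, carrying the same two amine groups, would help to settle. Also open, going by these compounds, is whether the lower number on the trifluoromethyl-bearing core stays with 4-methyl-1,4-diazepan-1-yl alone or extends to a longer chain between the two nitrogens.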